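From methyl to cyclopropyl on the shared core

This account rests on a few compounds, and the source may have more. Where it says the series, first, only, none or still open, it means among the compounds named here.

Going by the values given here, in an ADME assay on HEp-2 cells (Homo sapiens) for cytotoxicity (on this read-out lower numbers stand for higher toxicity in this test and higher numbers for lower toxicity in this test), compound 1 (`CN1C(=O)N(Cc2nc3ccccc3n2CCCCF)c2ccccc2S1(=O)=O`) reads 87700 nM and holds the higher of the two numbers so far, while compound 2 (`CN1C(=O)N(Cc2nc3ccccc3n2CCCS(C)(=O)=O)c2ccccc2S1(=O)=O`) reads 34500 nM on the same scale. Among the compounds with values here, the only measured step puts methylsulfonyl in place of fluoromethyl on the chain and amounts to a 2.5-fold lower number from compound 1 to compound 2 (0.41 log units; beyond the scatter) in this read-out. Compound 3 (`O=C1N(Cc2nc3ccccc3n2CCCCF)c2ccccc2S(=O)(=O)N1C1CC1`) has not been measured yet. It carries cyclopropyl in place of methyl on an amide-type nitrogen in a ring and otherwise matches compound 1. Within the data shown here, no measured step touches that nitrogen, so the data offer no direct guide to this change. The chain step from compound 1 to compound 2, at a 2.5-fold lower number from compound 1 to compound 2 (0.41 log units; beyond the scatter) as the sole yardstick, suggests that modest moves are what this series has shown so far. The expected move is a 1.3-fold lower number from compound 1 to compound 3 (0.10 log units; within the scatter) and it may well stay within the scatter, with only a tentative lean toward a lower number. Compound 3 is estimated at 70000 nM with 30000 nM to 150000 nM as the expected range.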

Compound 3, half-maximal cytotoxic concentration: 111000 nM
Compound 3: the middle estimate sits 1.6-fold (0.20 log units) below what was measured, within the range that was stated.
By their numbers in this assay, from the lowest: compound 2; then compounds 1 and 3 (each within the scatter of the next).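

Going by these compounds alone, this is the first look at the amide-type nitrogen next to the ring sulfur, and in this assay the swap from methyl to cyclopropyl gives a 1.3-fold higher number from compound 1 to compound 3 (0.10 log units; within the scatter). The entering group brings more carbon and a three-membered ring, yet this read-out does not separate the two compounds, so on the fluorinated chain this nitrogen accepts cyclopropyl without a change that can be told from ordinary scatter. The only step beyond the scatter among the compounds shown remains the one on the chain, a 2.5-fold lower number from compound 1 to compound 2 (0.41 log units; beyond the scatter), and nothing available explains why the swap on the nitrogen leaves the read-out where it is.

As far as these compounds go, it remains open whether a larger group on that nitrogen, such as a phenyl ring or a longer carbon chain, would also stay within the scatter of compound 1. From the compounds shown here alone, it is equally open whether cyclopropyl would behave the same way on the nitrogen of compound 2, which carries the methylsulfonyl chain.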